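Aryl replacements for cyclopentylmethyl in this series

The source may hold more compounds than are shown below. What is called first, only, known or untested is meant among the compounds shown, and "the series" means these compounds.

Measured so far:
compound 1 `C[C@H](NC(=O)C(=O)NCCC1CCCC1)C(=O)N[C@@H](CC(=O)O)C(=O)COc1c(F)c(F)cc(F)c1F` — 11 nM
compound 2 `Cc1ccccc1CNC(=O)C(=O)N[C@@H](C)C(=O)N[C@@H](CC(=O)O)C(=O)COc1c(F)c(F)cc(F)c1F` — 52 nM
compound 3 `Cc1ccc(CNC(=O)C(=O)N[C@@H](C)C(=O)N[C@@H](CC(=O)O)C(=O)COc2c(F)c(F)cc(F)c2F)cc1C` — > 10000 nM, a limit of the assay and not a number

In a functional assay on Jurkat cells (Homo sapiens) (on this read-out lower numbers stand for stronger inhibition and higher numbers for weaker inhibition), compound 1 gives the lowest of the two numbers shown, with compound 2 as its nearest neighbour. Compound 3 sits at the limit of > 10000 nM in this assay, at which 1 of the 3 values shown sits.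

Compound 4 `C[C@H](NC(=O)C(=O)NCc1cccc(Cl)c1Cl)C(=O)N[C@@H](CC(=O)O)C(=O)COc1c(F)c(F)cc(F)c1F` differs from compound 1 by 2,3-dichlorophenyl in place of cyclopentylmethyl on a saturated chain carbon bound to an amide-type nitrogen. Among the measured compounds shown here, the steps that bear on this change both replace cyclopentylmethyl by an aromatic ring: a 4.7-fold higher number from compound 1 to compound 2 (0.67 log units; beyond the scatter), and an at least 900-fold higher number from compound 1 to compound 3 (2.95 log units; beyond the scatter). Between the two aromatic variants themselves, an at least 190-fold higher number from compound 2 to compound 3 (2.28 log units; beyond the scatter). For the measured compounds named here, every aromatic ring tried at this position so far has raised the number, by a modest step for 2-methylphenyl and by a large one for 3,4-dimethylphenyl, so a higher number than for compound 1 is expected for compound 4, with the size of the step uncertain between these two precedents. The expected step is an 11-fold higher number from compound 1 to compound 4 (1.04 log units; beyond the scatter). For compound 4 the estimated value in this assay is 120 nM, with a range from 20 nM to 2500 nM.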

Compound 4, half-maximal inhibitory concentration: 76 nM
The estimate for compound 4 lay 1.6-fold (0.20 log units) above the measured number; the measured number falls inside the stated range.
By their numbers in this assay, from the lowest: compound 1; then compounds 2 and 4 (each within the scatter of the next). At a limit, above all of these: compound 3.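

With a 1.5-fold higher number from compound 2 to compound 4 (0.16 log units; within the scatter), the 2,3-dichlorophenyl and 2-methylphenyl groups cannot be told apart on this read-out. With a 6.9-fold higher number from compound 1 to compound 4 (0.84 log units; beyond the scatter), compound 4 gives a second modest step away from cyclopentylmethyl, so among the listed compounds the large step is confined to 3,4-dimethylphenyl and does not extend to every aromatic ring at this place. Compound 3 remains at a limit of the assay and not a number, with an at least 130-fold lower number from compound 3 to compound 4 (2.11 log units; beyond the scatter): the limit of > 10000 nM in this assay, at which 1 of the 4 values shown sits.

The compounds shown leave open whether 3,4-dimethylphenyl differs from 2,3-dichlorophenyl through its methyl groups or through where they stand, a question that 3,4-dichlorophenyl or 2,3-dimethylphenyl would address. Also open, going by these compounds, is whether an amine or a carboxylic acid on the aromatic ring, or a longer chain leading to it, would bring the number back towards that of cyclopentylmethyl.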